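Amide Variation on a Shared Core: Cytotoxicity Outlook

The source may hold more compounds than are shown below. What is called first, only, known or untested is meant among the compounds shown, and "the series" means these compounds.

Compound 1, `CCCCCC(=O)Nc1cc2nc(C3CCCCC3)[nH]c2cc1N(C)C`: > 100 ug/mL
Compound 2, `CN(C)c1cc2[nH]c(C3CCCCC3)nc2cc1NC(=O)c1cccs1`: > 100 ug/mL
Compound 3, `CN(C)c1cc2[nH]c(C3CCCCC3)nc2cc1NC(=O)c1ccc(F)cc1F`: > 100 ug/mL

In an ADME assay on Vero cells (Chlorocebus sabaeus) for cytotoxicity, read by resazurin assay, with a stated time of 3 days (a higher number here means a weaker inhibitor, a lower number a stronger inhibitor), compound 1 gives > 100 ug/mL, which is a limit of the assay and not a number. Compound 2 gives > 100 ug/mL in this assay, again only a limit. Compound 3 likewise gives > 100 ug/mL, a limit. All three therefore sit at the limit of > 100 ug/mL in this assay, at which 3 of the 3 values shown sit, so compound 3 stands level with the other two as far as the numbers show. The measured steps a step that the two limits leave unreadable from compound 1 to compound 2, a step that the two limits leave unreadable from compound 1 to compound 3 and a step that the two limits leave unreadable from compound 2 to compound 3 are each unreadable in size and direction.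

Compound 4, `CN(C)c1cc2[nH]c(C3CCCCC3)nc2cc1NC(=O)c1ccco1`, differs from compound 3 by furan-2-yl in place of 2,4-difluorophenyl on a carbonyl carbon. Every step that bears on this change is hidden by the limits, so no direction can be read from them. The expected step is therefore a step that the limit leaves unreadable from compound 3 to compound 4, with the value of compound 4 most likely to be reported again as a limit. Compound 4 is estimated at 150 ug/mL, with a range from 60 ug/mL to 400 ug/mL.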

Compound 4, half-maximal inhibitory concentration: > 100 ug/mL
Compound 4 was reported as a limit (the forecaster's own chance of this, stated with the estimate: 85%); the middle value lies beyond the limit too.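

The steps from compound 1, compound 2 and compound 3 to compound 4 cannot be read in size or direction, as all four compounds share one limit: the limit of > 100 ug/mL in this assay, at which 4 of the 4 values shown sit.

In this assay the compounds shown leave open whether the pentyl, thiophen-2-yl, 2,4-difluorophenyl and furan-2-yl amides differ at all.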